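The compounds below may be only part of what the source reports. "The series", "measured", "known", "first", "only" and "open" are said of these compounds alone.

In an ADME assay on liver for metabolic stability, with Liver microsome (Rattus norvegicus) as the target, using microsomes and NADPH, with a stated time of 30 min, tested at 0.5 uM (a lower number here means slower removal, a higher number faster removal of the compound), three compounds have been measured so far. Compound 1 `O=C1NCCN1CCOc1nn(-c2ccccc2F)c2ccc(F)cc12` gives 1380 mL/min/kg, compound 2 `O=C1N(c2ccncc2)CCN1c1cccc2c1cnn2-c1ccccc1F` gives 228 mL/min/kg, and compound 3 `O=C1N(Cc2ncco2)CCN1c1cccc2c1cnn2-c1ccccc1F` gives 100 mL/min/kg, the lowest of the three numbers. The next compound to test is compound 4 `CC(C)(C)OC(=O)N1CCN(c2cccc3c2cnn3-c2ccccc2F)C1=O`, which carries tert-butoxycarbonyl in place of (1,3-oxazol-2-yl)methyl on an amide-type nitrogen in a ring.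

Among the compounds with values here, only one measured step changes the group at this same place: a 2.3-fold lower number from compound 2 to compound 3 (0.36 log units; beyond the scatter), a modest change but beyond the usual scatter. It shows that the number can respond to the group on this nitrogen, though it cannot say how a group with no ring will behave. Compound 3 already stands lowest at 100 mL/min/kg, so a rise seems more likely than a further fall. A modest upward change of similar size is expected, estimated as a 2.5-fold higher number from compound 3 to compound 4 (0.40 log units; beyond the scatter). For compound 4, the estimated clearance is 250 mL/min/kg, with an expected range of 100 mL/min/kg to 650 mL/min/kg.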

Compound 4, clearance: 120 mL/min/kg
For compound 4 the middle estimate is 2.1-fold (0.32 log units) above the measured one; the range from low to high includes it.
By their numbers in this assay, from the lowest: compounds 3, 4 and 2 (each within the scatter of the next, the first and the last beyond it); then compound 1.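

In this assay, placing tert-butoxycarbonyl, which has no ring, on this amide-type nitrogen gives two small steps (a 1.2-fold higher number from compound 3 to compound 4 (0.08 log units; within the scatter); a 1.9-fold lower number from compound 2 to compound 4 (0.28 log units; within the scatter)). A group without a ring therefore gives a number that cannot be told apart from those of compound 2 and compound 3, even though those two differ from each other beyond the scatter, so a ring on this nitrogen is not required for a number in this range. Nothing available here explains this result.

The compounds shown leave open how the number would respond if this nitrogen carried an amine, a carboxylic acid or a longer chain. They also leave open whether any group at this place can bring the number clearly below that of compound 3 (100 mL/min/kg).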